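Taking the Methoxy Off Compound 2

This account rests on a few compounds, and the source may have more. Where it says the series, first, only, none or still open, it means among the compounds named here.

In an ADME assay (liver) for metabolic stability, with Liver microsome (Rattus norvegicus) as the target, read by LC-MS, using microsomes and NADPH, with stated times of 5 min and 60 min, tested at 4 uM (on this read-out lower numbers stand for a less stable compound and higher numbers for a more stable compound), compound 2 `COc1cc(C(=O)O)ccc1OCCCCOc1ccc(C(=O)CC(C)C)c(O)c1C` reaches 43% and stands highest of three measured compounds. Its gaps to compound 1 `Cc1c(OCCCCOCOc2ccc(C(=O)O)cc2)ccc(C(=O)CC2CCCC2)c1O` at 31% and to compound 3 `Cc1c(OCCCCOc2cccc(C(=O)O)c2)ccc(C(=O)CC(C)C)c1C` at 29% both lie beyond the scatter.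

Compound 4 `Cc1c(OCCCCOc2ccc(C(=O)O)cc2)ccc(C(=O)CC(C)C)c1O` has not yet been measured. Its change from compound 2 is hydrogen in place of methoxy on an aromatic carbon and amounts to hydrogen in place of methoxy on an aromatic carbon.

Among the measured compounds shown here, no two measured compounds differ in one place only, so this change has no direct precedent. Compound 1 at 31% and compound 3 at 29% also lack the methoxy and both sit lower than compound 2, but they differ from it elsewhere too, which makes this only a weak hint. A small fall in this assay is expected, about the size of the usual scatter, with the estimated change being a number 8 percentage points lower from compound 2 to compound 4 (within the scatter) and not a certain one. Compound 4 is estimated at 35% with 22% to 48% as the expected range.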

Compound 4, percent of the compound remaining: 66%
Estimate against measurement, compound 4: 31 percentage points below; measured number outside the range, above it.
By their numbers in this assay, from the lowest: compounds 3 and 1 (each within the scatter of the next); then compound 2; then compound 4.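

In this assay, replacing the methoxy with hydrogen on this aromatic carbon gives a clear rise, a number 23 percentage points higher from compound 2 to compound 4 (beyond the scatter). Among the compounds shown here, this is the first pair of compounds that differ in one place only, so it shows directly that the group on this carbon, ortho to a large group and meta to a carboxy group, can shift the read-out beyond the usual scatter. No measurement shown here explains why the number rises.

This single pair cannot show whether the rise would hold if other parts of the molecule were changed as well. It also leaves open how the read-out would respond to a fluorine atom or an ethoxy group on the same carbon, and whether either would land nearer to hydrogen or to methoxy.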